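The source may report more compounds than this note shows. Statements on the series, on what has been measured and on what is new or still open speak of the compounds shown alone.

Working notes on the series

Compound 3, `NC(=O)C[C@H](NC(=O)CN(c1nc(Cl)nc2[nH]cnc12)C1CC1)C(=O)O`, gives 43.1% in a functional assay on the whole organism (Tail, strain ICR) with Mus musculus as the target, in the tail flick test, with a stated time of 60 min, at a dose of 25 umol/kg by the oral route; on this read-out higher numbers stand for a stronger effect at the one dose given and lower numbers for a weaker effect. Among the measured compounds shown here, it holds the highest of the three numbers so far, though only its gap to compound 1 lies beyond the scatter: compound 1, `C[C@@H](O)[C@H](NC(=O)CN(c1nc(Cl)nc2[nH]cnc12)C1CC1)C(=O)O`, gives 30.1%, and the step is a number 13 percentage points higher from compound 1 to compound 3 (beyond the scatter). Compound 2, `O=C(O)C[C@H](NC(=O)CN(c1nc(Cl)nc2[nH]cnc12)C1CC1)C(=O)O`, gives 38.9%; the step of a number 4.2 percentage points higher from compound 2 to compound 3 (within the scatter) sits within the scatter, as does a number 8.8 percentage points higher from compound 1 to compound 2 (within the scatter).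

Compound 4 is `NCCCC[C@H](NC(=O)CN(c1nc(Cl)nc2[nH]cnc12)C1CC1)C(=O)O`. Its difference from compound 3 is 3-aminopropyl in place of carbamoyl on a saturated chain carbon, two bonds along the chain from an amide-type nitrogen and a carbonyl carbon. For the measured compounds named here, all three measured steps alter the same side chain, yet none of them brings in a 3-aminopropyl, so no direct precedent exists. Going by the values given here, of those steps only the one from compound 1 to compound 3 crossed the scatter, and it was modest; the two others stayed within it. The side chain therefore appears to move this read-out little, and the expected step is a number 1.1 percentage points lower from compound 3 to compound 4 (within the scatter), nothing beyond the scatter in either direction. For compound 4 the estimate is 42%, with a range from 24% to 60%.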

Compound 4, a percentage reported as activity, at one dose (the size of the read-out at that dose, not a potency): 53.8%
Estimate against measurement, compound 4: 11.8 percentage points below, within the range that was stated.
By their numbers in this assay, from the lowest: compounds 1, 2 and 3 (each within the scatter of the next, the first and the last beyond it); then compound 4.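

In this assay the change to the 4-aminobutyl side chain of compound 4 lies beyond the scatter against every earlier compound, with a number 10.7 percentage points higher from compound 3 to compound 4 (beyond the scatter) and a number 14.9 percentage points higher from compound 2 to compound 4 (beyond the scatter) and a number 23.7 percentage points higher from compound 1 to compound 4 (beyond the scatter) as the three readings. Among the compounds shown here, this position on the saturated chain carbon bound to an amide-type nitrogen and a carbonyl carbon therefore carries more of the read-out than the earlier compounds showed, since compound 4 is the first to stand clear of all the others. No measurement given here bears on why this change raises the number.

Going by these compounds, whether the gain follows the terminal amine or the chain length stays open, and a plain butyl chain or a shorter or longer aminoalkyl chain would separate the two. With one dose and one time, the compounds shown also leave potency open.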